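The source may hold more compounds than are shown below. What is called first, only, known or untested is meant among the compounds shown, and "the series" means these compounds.

Two compounds set the scene. Compound 1 `CC(c1ccc(-c2ccccc2)c(F)c1)c1nnc2n1N=C(c1ccc(OC(F)(F)F)cc1)CS2` in a functional assay on HCT-116 cells (Homo sapiens) for inhibition, read by sulforhodamine B assay, with a stated time of 72 h (on this read-out higher numbers stand for weaker inhibition and lower numbers for stronger inhibition), gives 5400 nM. Compound 2 `CC(c1ccc(-c2ccccc2)c(F)c1)c1nnc2n1N=C(c1ccc(C(F)(F)F)cc1)CS2` in this assay gives 6100 nM. Going by the values given here, the one step measured so far, a 1.1-fold higher number from compound 1 to compound 2 (0.05 log units; within the scatter), came with trifluoromethyl in place of trifluoromethoxy on an aromatic carbon, and on these numbers compound 2 and compound 1 sit within the scatter of each other, so neither can be set apart from the other.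

Compound 3 `CC(c1ccc(-c2ccccc2)c(F)c1)c1nnc2n1N=C(c1ccc(Cl)cc1)CS2` has not yet been measured. Its difference from compound 2 is chloro in place of trifluoromethyl on an aromatic carbon, para to a large group, which read one bond further out is 4-(trifluoromethyl)phenyl to 4-chlorophenyl. Among the compounds with values here, the only step that bears on this place is a 1.1-fold higher number from compound 1 to compound 2 (0.05 log units; within the scatter), a swap of one small group for another on the same aromatic carbon that left the numbers inside the scatter. With just that to go on, the step expected in this assay is a 1.0-fold lower number from compound 2 to compound 3 (0.01 log units; within the scatter), none beyond the scatter. Compound 3 is therefore estimated at 6000 nM, with a range from 2500 nM to 14000 nM.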

Compound 3, half-maximal inhibitory concentration: 7800 nM
The estimate for compound 3 lay 1.3-fold (0.11 log units) below the measured number; the range from low to high includes it.
By their numbers in this assay, from the lowest: compounds 1, 2 and 3 (each within the scatter of the next).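

At this place, on an aromatic carbon para to a large group, the change is now from trifluoromethyl, with 4 heavy atoms, to chloro, with 1 heavy atom, and in this assay it gives a 1.3-fold higher number from compound 2 to compound 3 (0.11 log units; within the scatter) and so stays within the scatter. Measured against trifluoromethoxy, the same chloro gives a 1.4-fold higher number from compound 1 to compound 3 (0.16 log units; within the scatter) and also stays within the scatter, so a second and a third group exchange at this place now agree with the first step. With all three pairs inside the scatter, none of these three groups can be set apart from the others at this place in this assay, and no measurement is available that would explain this result.

On these data alone, whether an amine, a carboxylic acid or a longer chain on this aromatic carbon would move the number beyond the scatter remains open, and so does the effect of a bare hydrogen there. The three compounds also share the rest of their structure, so they leave open how much changes elsewhere on the molecule would matter for inhibition of these cells.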